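From 3,5-dimethoxyphenyl to 3-chloro-4-fluorophenyl

A few compounds are considered here, and "the series" means these few. Any claim that something is new, unique, unknown or untested is made for them only; others in the source may bear on it.

Compound 3 (`COc1cc(CNc2ncnc3c2ncn3[C@@H]2O[C@H](CO)[C@@H](O)[C@H]2O)cc(OC)c1`) offers no number to start from. In an ADME assay on NIH3T3 cells (Mus musculus) for cytotoxicity, with a stated time of 72 h (on this read-out lower numbers stand for stronger inhibition and higher numbers for weaker inhibition), the entry for compound 3 reads "not determined" (no result reported) and gives neither a value nor a limit. Its closest measured relatives give limits only. Compound 1 (`OC[C@H]1O[C@@H](n2cnc3c(NCc4ccccc4F)ncnc32)[C@H](O)[C@@H]1O`), which carries 2-fluorophenyl, gives a limit (> 166000 nM) and no number. Compound 2 (`Cc1cccc(CNc2ncnc3c2ncn3[C@@H]2O[C@H](CO)[C@@H](O)[C@H]2O)c1`) also gives a limit (> 166000 nM) and no number.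

Compound 4 (`OC[C@H]1O[C@@H](n2cnc3c(NCc4ccc(F)c(Cl)c4)ncnc32)[C@H](O)[C@@H]1O`) differs from compound 3 in one group on a saturated chain carbon bound to a nitrogen on an aromatic ring (3-chloro-4-fluorophenyl in place of 3,5-dimethoxyphenyl on a saturated chain carbon bound to a nitrogen on an aromatic ring). Going by the values given here, the only measured step (a step that the two limits leave unreadable from compound 1 to compound 2) has no readable size, and both measured values rest on the same limit (the limit of > 166000 nM in this assay, at which 2 of the 3 values shown sit). No step beyond the scatter can therefore be expected in this assay, in either direction, and the reading for compound 4 is expected to stay at or near that limit. Compound 4 is estimated at about 180000 nM with an expected range from 70000 nM to 300000 nM in this estimate.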

Compound 4, half-maximal inhibitory concentration: > 166000 nM
Compound 4 was reported as a limit; the forecaster's own chance of this, stated with the estimate: 80%; the middle value is on the limit's open side.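

Compound 1, compound 2 and compound 4 each give only a limit in this assay, so no step among them can be read: the limit of > 166000 nM in this assay, at which 3 of the 4 values shown sit.

The compounds shown leave open whether any group at this place on the shared core gives a readable number in this assay, and where compound 3 stands.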